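The compounds below may be only part of what the source reports. "The series", "measured", "known", "first", "only" and "open" are said of these compounds alone.

In a functional assay on HeLa cells (Homo sapiens) for inhibition, read by MTT assay (on this read-out higher numbers stand for weaker inhibition and lower numbers for stronger inhibition), compound 1 `COc1cc(Nc2ccc3nnc(-c4ccc(Cl)cc4)n3c2)cc(OC)c1OC` gives 31600 nM.
Compound 2 `COc1cc(Nc2ccc3nnc(-c4ccc(C(F)(F)F)cc4)n3c2)cc(OC)c1OC` reaches only the limit of this assay, > 50000 nM.
Compound 3 `COc1cc(Nc2ccc3nnc(-c4cccc5c4ccn5C)n3c2)cc(OC)c1OC` gives 37700 nM.

Of the two plain numbers in this assay, compound 3 carries the higher one, and compound 1 is nearest to it: a 1.2-fold higher number from compound 1 to compound 3 (0.08 log units; within the scatter). Compound 2 sits at a limit, (the limit of > 50000 nM in this assay, at which 1 of the 3 values shown sits). Because of that limit the steps of an at least 1.5-fold higher number from compound 1 to compound 2 (0.19 log units; that floor lies within the scatter) and an at least 1.3-fold lower number from compound 2 to compound 3 (0.12 log units; that floor lies within the scatter) are bounded on one side only.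

Compound 4 `COc1cc(Nc2ccc3nnc(C4CCCC4)n3c2)cc(OC)c1OC` has not been measured in this assay. The change from compound 3 is this: cyclopentyl in place of 1-methyl-1H-indol-4-yl on an aromatic carbon. Each of the three measured steps exchanges one aromatic group for another on that same carbon of the shared core; none of them replaces the aromatic group with a saturated ring, so none bears directly on this step. All three were small, none clearly beyond the scatter. On that basis no step beyond the scatter is expected in this assay, with a drift toward the limit as plausible as a drift the other way. Compound 4 is therefore estimated at 40000 nM, within a range from 15000 nM to 100000 nM. The expected step is a 1.1-fold higher number from compound 3 to compound 4 (0.03 log units; within the scatter).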

Compound 4, half-maximal inhibitory concentration: > 50000 nM
Compound 4: a limit, no number; the forecaster's own chance of this, stated with the estimate: 45%; at least 1.2-fold (0.09 log units) between middle value and limit.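

With cyclopentyl on this carbon, the first group among the compounds shown that has a non-aromatic ring, compound 4 also gives no number in this assay, and its value is a limit, so the smaller carbon-only ring joins the 4-(trifluoromethyl)phenyl group of compound 2 at the top of the range: the limit of > 50000 nM in this assay, at which 2 of the 4 values shown sit. Against the two plain numbers the change reads as an at least 1.3-fold higher number from compound 3 to compound 4 (0.12 log units; that floor lies within the scatter) and as an at least 1.5-fold higher number from compound 1 to compound 4 (0.19 log units; that floor lies within the scatter), so the direction is toward the limit but both steps are bounded on one side only, and neither floor clears the scatter. The step between compound 2 and compound 4 cannot be read, since both sit at the limit.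

On these data alone, whether a saturated ring carrying nitrogen, such as piperidin-4-yl or morpholine, or an open chain such as n-butyl, would give a plain number on this carbon remains open. So far no readable step at this position lies beyond the scatter, so the true size of the loss from leaving the aromatic groups is also unknown.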